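This account rests on a few compounds, and the source may have more. Where it says the series, first, only, none or still open, it means among the compounds named here.

Working notes on the series. Compound 2 `Clc1cc(Cl)cc(CO[C@H]2CCCN(Cc3ccc(-c4nn[nH]n4)cc3)[C@H]2c2ccccc2)c1` is the reference point here. In an assay on isolated protein for activation of cGMP-dependent protein kinase 1 (Homo sapiens), read by ADP-Glo, with stated times of 120 min and 40 min (a higher number here means that more compound is needed for the effect, a lower number that less compound is needed), compound 2 gives 74000 nM, the lower of the two numbers recorded, though its gap to compound 3 is within the scatter. Compound 3 `OC[C@@H](O[C@H]1CCCN(Cc2ccc(-c3nn[nH]n3)cc2)[C@H]1c1ccccc1)c1cc(Cl)cc(Cl)c1` gives 131000 nM in this assay, and the step of a 1.8-fold higher number from compound 2 to compound 3 (0.25 log units; within the scatter). Compound 1 `Clc1cc(Cl)cc(CO[C@H]2CCCN(Cc3ccccn3)[C@H]2c2ccccc2)c1` reaches only a limit of this assay, > 200000 nM, which the limit of > 200000 nM in this assay, at which 1 of the 3 values shown sits, records. Going by the values given here, the step of an at least 2.7-fold lower number from compound 1 to compound 2 (0.43 log units; beyond the scatter) is the one measured change at the same place as the change now in question.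

Compound 4 `O=C(O)c1cncc(CN2CCC[C@H](OCc3cc(Cl)cc(Cl)c3)[C@@H]2c2ccccc2)c1` differs from compound 2 as follows: 5-carboxypyridin-3-yl in place of 4-(2H-tetrazol-5-yl)phenyl on a saturated chain carbon bound to an amine nitrogen in a ring. The measured step from compound 1 to compound 2 shows that an acidic aromatic group at this place gave an at least modest lowering of the number relative to a plain pyridin-2-yl, while compound 4 carries a different acidic group on a pyridine ring. Among the compounds with values here, no measured step tests a carboxylic acid here, so the expectation is a step of a 1.6-fold higher number from compound 2 to compound 4 (0.21 log units; within the scatter) that may go either way and is expected to stay near or within the scatter. Compound 4 is therefore estimated at 120000 nM, with a range from 40000 nM to 300000 nM.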

Compound 4, half-maximal effective concentration: 117000 nM
Compound 4: middle estimate off by 1.0-fold (0.01 log units), on the high side; the range from low to high includes it.
By their numbers in this assay, from the lowest: compounds 2, 4 and 3 (each within the scatter of the next). At a limit, above all of these: compound 1.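

At this place, on a saturated chain carbon bound to an amine nitrogen in a ring, 5-carboxypyridin-3-yl and 4-(2H-tetrazol-5-yl)phenyl cannot be told apart in this assay, with a 1.6-fold higher number from compound 2 to compound 4 (0.20 log units; within the scatter). Going by these compounds alone, the tetrazole is therefore not the only group here that gives a number of this size, and one six-membered aromatic ring serves as well as the two rings of the group it replaces. The step from pyridin-2-yl is an at least 1.7-fold lower number from compound 1 to compound 4 (0.23 log units; that floor lies within the scatter), and it rests on a limit: the limit of > 200000 nM in this assay, at which 1 of the 4 values shown sits.

A carboxylic acid on a plain phenyl ring and a tetrazole on a pyridine ring would separate the two differences that compound 4 carries at once. Also open, as far as these compounds go, is how a methyl ester or a primary amine at this place would read.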